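Adding a 2-methylphenyl ring to the nitrogen-bound chain

The compounds below may be only part of what the source reports. "The series", "measured", "known", "first", "only" and "open" are said of these compounds alone.

Measured so far:
compound 1, `CCn1c(CN2CCN(C(=O)C3CC3)CC2)nc2ccccc21`, 20.8%
compound 2, `Cc1cccc(Cn2c(CN3CCN(C(=O)c4cccnc4)CC3)nc3ccccc32)c1`, 24.5%
compound 3, `Cc1cccc(Cn2c(CN3CCN(C(=O)c4ccc(C(C)C)cc4)CC3)nc3ccccc32)c1`, 67.6%

All three compounds share one core and were tested in an assay on isolated protein for inhibition of aldehyde dehydrogenase 1A1 (Homo sapiens), read by spectrophotometry, tested at 10 uM; on this read-out higher numbers stand for more inhibition at the one concentration tested (going by the name of the read-out) and lower numbers for less inhibition. Compound 1 stands lowest of the three numbers with 20.8%. Its nearest neighbour is compound 2, whose value lies within the usual scatter of that of compound 1, so no order can be read between them. Compound 3 lies well beyond the scatter above compound 1. Among the compounds with values here, the only step that can be followed directly, a number 43.1 percentage points higher from compound 2 to compound 3 (beyond the scatter), changes the group on the carbonyl carbon, not the chain bound to the aromatic nitrogen.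

Compound 4, `Cc1ccccc1Cn1c(CN2CCN(C(=O)C3CC3)CC2)nc2ccccc21`, is not yet measured. It differs from compound 1 in one place: 2-methylphenyl in place of methyl on a saturated chain carbon bound to an aromatic nitrogen. Within the data shown here, no measured pair changes this part of the molecule, so the one known step does not bear on it. Compounds 2 and 3 both carry a methylbenzyl group at this chain and give a low and a high value, which shows that this group alone does not fix the read-out. Compound 4 is therefore expected to give a step of a number 9.2 percentage points higher from compound 1 to compound 4 (within the scatter), with a rise possible but uncertain. The estimate for compound 4 is 30%, with a range from 10% to 55%.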

Compound 4, a percentage reported as inhibition, at one concentration (the size of the read-out at that concentration, not a potency): 29.1%
Estimate against measurement, compound 4: 0.9 percentage points above; low and high end bracket the measured number.
By their numbers in this assay, from the lowest: compounds 1, 2 and 4 (each within the scatter of the next); then compound 3.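

In this assay, within the data shown here, 2-methylphenyl in place of methyl on a saturated chain carbon bound to an aromatic nitrogen gives a number 8.3 percentage points higher from compound 1 to compound 4 (within the scatter), the first step that can be followed at this position. With the rest of the molecule held the same, the small ethyl chain and the 2-methylbenzyl group, which brings a six-membered aromatic ring of carbon only, cannot be told apart here, so neither a gain nor a loss of inhibition can be read from this change. No measured evidence bears on why the exchange reads this way.

The compounds shown leave open whether this position would respond to a different kind of group, such as an amine or a carboxylic acid on the chain, or a longer chain ending in a phenyl ring. They also leave open whether the same exchange would read alike with 4-isopropylphenyl on the carbonyl carbon, as the step here carries only the carbonyl group shared by compound 1 and compound 4.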